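Two limits and a methyl for trifluoromethyl

This account rests on a few compounds, and the source may have more. Where it says the series, first, only, none or still open, it means among the compounds named here.

Compound 1 `CCN(CC)c1ccc2cc(C(=O)c3ccc(N4CCN(S(=O)(=O)c5ccc([N+](=O)[O-])cc5)CC4)cc3)oc2c1` in a functional assay on MCF7 cells (Homo sapiens) for cytotoxicity, read by MTT assay, with a stated time of 48 h (a lower number here means a stronger inhibitor, a higher number a weaker inhibitor), gives > 40000 nM, a limit of the assay.
Compound 2 `CCN(CC)c1ccc2cc(C(=O)c3ccc(N4CCN(S(=O)(=O)c5ccc(C(F)(F)F)cc5)CC4)cc3)oc2c1` in this assay gives > 40000 nM, also a limit.

Among the compounds with values here, compound 2 therefore stands at a limit and not at a number, and the only measured step, a step that the two limits leave unreadable from compound 1 to compound 2, cannot be read in size because of the limit of > 40000 nM in this assay, at which 2 of the 2 values shown sit. Compound 3 `CCN(CC)c1ccc2cc(C(=O)c3ccc(N4CCN(S(=O)(=O)c5ccc(C)cc5)CC4)cc3)oc2c1` differs from compound 2 by methyl in place of trifluoromethyl on an aromatic carbon. Within the data shown here, no measured step shows how a methyl in place of trifluoromethyl moves this assay, so the step from compound 2 to compound 3 is expected to be one the assay again leaves unreadable, and no direction beyond the scatter is expected for it, as a step that the limit leaves unreadable from compound 2 to compound 3. Compound 3 is accordingly expected at 60000 nM, within 20000 nM to 200000 nM, most likely reported again as a limit.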

Compound 3, half-maximal inhibitory concentration: > 40000 nM
Compound 3: only a limit was reported (the forecaster's own chance of this, stated with the estimate: 80%); the middle value is on the limit's open side.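

Within the data shown here, compound 3 also sits at a limit in this assay, so no step among compound 1, compound 2 and compound 3 can be read in size: the limit of > 40000 nM in this assay, at which 3 of the 3 values shown sit.

The compounds shown leave open how nitro, trifluoromethyl and methyl compare, since none of the three has a measured number.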